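Piperazinyl replacement on a bromo-substituted amide series

The compounds below may be only part of what the source reports. "The series", "measured", "known", "first", "only" and "open" are said of these compounds alone.

Three compounds share the amide core. Compound 1 `C[C@@H](CO)Nc1nc(C(=O)NCc2ccc(F)cc2)c(O)c2ncccc12` carries a hydroxy-bearing variant of it; in a functional assay on HCT-116 cells (Homo sapiens) for cytotoxicity, read by MTT assay, with a stated time of 72 h (on this read-out lower numbers stand for stronger inhibition and higher numbers for weaker inhibition), compound 1 gives "not determined" (no result reported). Going by the values given here, compound 2 `C[C@@H](Nc1c(C(=O)NCc2ccc(F)cc2)nc(Br)c2cccnc12)c1ccccc1` is the only member with any read-out. In this assay compound 2 gives > 20000 nM, which is a limit of the assay and not a number. Compound 2 thus stands at the limit of > 20000 nM in this assay, at which 1 of the 2 values shown sits, and no single number is available in this assay for any member of the series. Compound 3 `O=C(NCc1ccc(F)cc1)c1nc(Br)c2cccnc2c1N1CCNCC1` differs from compound 2 in one place: piperazin-1-yl in place of (1-phenylethyl)amino on an aromatic carbon. Among the compounds with values here, no step between measured compounds exists, so the size of this change in this assay cannot be read from the series; the expected step is a number no higher from compound 2 to compound 3 (the limit leaves the size open), which is nothing beyond the usual scatter. Compound 3 is expected to give 20000 nM, within 5000 nM to 60000 nM, with a limit remaining the likely outcome.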

Compound 3, half-maximal inhibitory concentration: > 10000 nM
Compound 3: no number, only a limit; the forecaster's own chance of this, stated with the estimate: 60%; the middle value does not contradict the limit.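

In this assay, going by these compounds alone, compound 2 and compound 3 both stand only at limits of the assay, and no step between them can be read. Still open, from the compounds shown here alone, is what piperazin-1-yl in place of (1-phenylethyl)amino does to a single number in this assay.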